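This account rests on a few compounds, and the source may have more. Where it says the series, first, only, none or still open, it means among the compounds named here.

The measured compounds, with their largest response in an assay on HEK293 cells for positive allosteric modulation of metabotropic glutamate receptor 2 (Rattus norvegicus), read by thallium flux, with a stated time of 2.5 min; a lower number here means a smaller maximal response, a higher number a larger maximal response:

compound 1, `COC(=O)c1ccc(OCCCCOc2ccc(C(=O)CC3CCCC3)c(O)c2C)cc1`: 12.2%
compound 2, `Cc1c(OCCCCOc2ccccc2C(=O)O)ccc(C(=O)CC2CCCC2)c1O`: 98.8%
compound 3, `COc1ccc(C(=O)O)cc1OCCCCOc1ccc(C(=O)CC2CCCC2)c(O)c1C`: 91.8%

Compound 3 holds the second highest of the three numbers. Its nearest neighbour is compound 2, and the step of a number 7 percentage points lower from compound 2 to compound 3 (within the scatter) lies within the scatter. Its furthest is compound 1, and the step of a number 79.6 percentage points higher from compound 1 to compound 3 (beyond the scatter) is large and beyond the scatter.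

Compound 4, `Cc1c(OCCCCOc2ccc(C(=O)O)c(Cl)c2)ccc(C(=O)CC2CCCC2)c1O`, has not yet been measured in this assay. It differs from compound 3 in one place: 4-carboxy-3-chlorophenyl in place of 5-carboxy-2-methoxyphenyl on an oxygen on a saturated carbon.

Within the data shown here, two measured steps bear on this change. Both a number 86.6 percentage points higher from compound 1 to compound 2 (beyond the scatter) and a number 79.6 percentage points higher from compound 1 to compound 3 (beyond the scatter) show that exchanging a methoxycarbonyl-bearing phenyl for a carboxy-bearing phenyl raised the maximal response by a large amount. The step of a number 7 percentage points lower from compound 2 to compound 3 (within the scatter) shows that moving the carboxy group within the ring, together with a methoxy group, stayed within the scatter. Compound 4 keeps a carboxy group and adds a chlorine, so no step beyond the scatter is expected in this assay, and a number 1.8 percentage points lower from compound 3 to compound 4 (within the scatter) is the estimated change.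

Compound 4 is therefore expected to give about 90%, with a plausible range from 70% to 105%.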

Compound 4, largest response reached (reported as percent of maximum), in percent of the reference or control that the assay uses: 80.8%
Beside the measured number, compound 4's estimate is 9.2 percentage points above it; the range from low to high includes it.
By their numbers in this assay, from the lowest: compound 1; then compound 4; then compounds 3 and 2 (each within the scatter of the next).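

In this assay, the carboxy-bearing groups on this oxygen turn out not to be interchangeable, as the earlier pair within the scatter might have suggested: 4-carboxy-3-chlorophenyl in place of 5-carboxy-2-methoxyphenyl gives a number 11 percentage points lower from compound 3 to compound 4 (beyond the scatter), and in place of 2-carboxyphenyl it gives a number 18 percentage points lower from compound 2 to compound 4 (beyond the scatter). Both steps are modest, so the identity of the ring substituents at this position can shift the maximal response even when a carboxy group is kept. The larger picture nevertheless holds for a third carboxy-bearing group, since 4-carboxy-3-chlorophenyl in place of 4-(methoxycarbonyl)phenyl gives a number 68.6 percentage points higher from compound 1 to compound 4 (beyond the scatter), a rise far greater than the loss seen against the other two acids.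

The compounds shown cannot separate the chlorine from the placing of the carboxy group, since the entering and leaving groups differ in both, and they leave open how a fluorine or a methyl in place of that chlorine, or a tetrazole or a primary amide in place of the carboxy group, would fare in this assay. Nothing presented here gives a reason for these steps.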